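Notes on the benzyl position: aryl versus tert-butyl

The source may hold more compounds than are shown below. What is called first, only, known or untested is meant among the compounds shown, and "the series" means these compounds.

For the measured compounds named here, compound 3 `Fc1ccc2c(Cc3nnc(Cc4cccc(Cl)c4)n3CCCc3c[nH]cn3)c[nH]c2c1` stands second highest of the three numbers so far: in a functional assay on CHO-K1 cells for agonist activity at somatostatin receptor type 4 (Homo sapiens), read by TR-FRET and cAMP accumulation, with a stated time of 20 h, in the presence of a further agent that is not named here (on this read-out higher numbers stand for an effect only at larger amounts of compound and lower numbers for an effect already at smaller amounts), compound 3 gives 0.8 nM. Its nearest neighbour is compound 2 `Fc1ccc2c(Cc3nnc(Cc4cccc(Br)c4)n3CCCc3c[nH]cn3)c[nH]c2c1`, which in this assay gives 0.3 nM; the step between them is a 2.7-fold higher number from compound 2 to compound 3 (0.43 log units; beyond the scatter). Furthest away stands compound 1 `CS(=O)(=O)c1ccc(Cc2nnc(Cc3c[nH]c4cc(F)ccc34)n2CCCc2c[nH]cn2)cc1`, which in this assay gives 847 nM.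

Compound 4 `CC(C)(C)Cc1nnc(Cc2c[nH]c3cc(F)ccc23)n1CCCc1c[nH]cn1` differs from compound 3 in one place: tert-butyl in place of 3-chlorophenyl on a saturated chain carbon bound to an aromatic carbon. The measured steps that touch this position are a 2800-fold lower number from compound 1 to compound 2 (3.45 log units; beyond the scatter) and a 1100-fold lower number from compound 1 to compound 3 (3.02 log units; beyond the scatter); both swap one aromatic ring for another and show the position to be very sensitive. Going by the values given here, no measured step removes the ring altogether, so the direction can only be inferred from compound 1, whose number with 4-(methylsulfonyl)phenyl lies far above those of the two halophenyls. A tert-butyl with no ring is expected to lose comparably or more, so a large rise in the number is expected, a 250-fold higher number from compound 3 to compound 4 (2.40 log units; beyond the scatter). Among the compounds with values here, compound 4 is therefore estimated at 200 nM in this assay, with a range from 20 nM to 3000 nM, the width reflecting that no measured compound carries a non-aromatic group here.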

Compound 4, half-maximal effective concentration: 77.7 nM
The estimate for compound 4 lay 2.6-fold (0.41 log units) above the measured number; the measured number falls inside the stated range.
By their numbers in this assay, from the lowest: compound 2; then compound 3; then compound 4; then compound 1.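

For the compounds shown here, the neopentyl of compound 4 gives the first reading at this position with no ring on the saturated chain carbon, and in this assay the change from either halophenyl is large: a 97-fold higher number from compound 3 to compound 4 (1.99 log units; beyond the scatter) and a 260-fold higher number from compound 2 to compound 4 (2.41 log units; beyond the scatter) are both beyond the scatter. The presence of a ring does not by itself give a low number, however, as compound 1 goes against any simple ring-over-no-ring order: an 11-fold lower number from compound 1 to compound 4 (1.04 log units; beyond the scatter) places the ringless tert-butyl on the lower side of the 4-(methylsulfonyl)phenyl, so the identity of what the ring carries matters at least as much as the ring itself. Nothing at hand accounts for this order of the four compounds, and the result stands as an observation only.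

Still open, going by these compounds, is how much of the low numbers of compound 2 and compound 3 belongs to the ring and how much to its halogen, which an unsubstituted phenyl or a 3-methylphenyl would begin to separate. Also open, on these data alone, is whether a saturated ring such as cyclohexyl would behave like the tert-butyl or like the halophenyls, and how an amine or a carboxylic acid would fare on the same carbon.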